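Removing the sulfamoyl of compound 3 in favour of fluoro

The compounds below may be only part of what the source reports. "The series", "measured", "known", "first", "only" and "open" are said of these compounds alone.

Three analogues of the shared core have been measured in a functional assay on HT-29 cells (Homo sapiens) for antiproliferative activity, read by sulforhodamine B assay, with a stated time of 72 h; a lower number here means a stronger inhibitor, a higher number a weaker inhibitor. Compound 1 `O=S(=O)(Nc1ccccn1)c1ccc(Nc2nncc3ccccc23)cc1` gives 38 nM. Compound 2 `Cc1cc(C)nc(NS(=O)(=O)c2ccc(Nc3nncc4ccccc34)cc2)n1` gives 3.3 nM, and compound 3 `NS(=O)(=O)c1ccc(Nc2nncc3ccccc23)cc1` gives 12 nM. Compound 3 thus holds the second highest number of the three: against compound 1 the step is a 3.2-fold lower number from compound 1 to compound 3 (0.50 log units; beyond the scatter), and against compound 2 it is a 3.6-fold higher number from compound 2 to compound 3 (0.56 log units; beyond the scatter). The largest step in the set is a 12-fold lower number from compound 1 to compound 2 (1.06 log units; beyond the scatter). All three steps concern only what sits on the sulfonamide nitrogen; the sulfamoyl itself is kept in every measured compound.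

Compound 4 `Fc1ccc(Nc2nncc3ccccc23)cc1` breaks from this pattern: fluoro in place of sulfamoyl on an aromatic carbon. Among the compounds with values here, no measured step removes the sulfamoyl, so the steps seen so far bear on the change only indirectly. They show that alterations at the sulfonamide nitrogen move the number by modest to large amounts, and a change that takes away the whole group and leaves a single fluorine atom is expected to be at least as consequential, with a higher number taken as the more likely direction. Compound 4 is therefore estimated at 60 nM, within a range of 8 nM to 400 nM, the expected step being a 5.0-fold higher number from compound 3 to compound 4 (0.70 log units; beyond the scatter).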

Compound 4, half-maximal inhibitory concentration: 2.1 nM
Compound 4: the middle estimate sits 29-fold (1.46 log units) above what was measured; measured number outside the range, below it.
By their numbers in this assay, from the lowest: compounds 4 and 2 (each within the scatter of the next); then compound 3; then compound 1.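

In this assay, the sulfamoyl is not required for a low number at this position: a 5.7-fold lower number from compound 3 to compound 4 (0.76 log units; beyond the scatter), with fluoro in its place on the aromatic carbon para to a large group. The earlier steps shown here changed only what sits on the sulfonamide nitrogen, whereas this step reads the position itself and shows that a single fluorine atom, with 0 hydrogen-bond donors and 0 hydrogen-bond acceptors, suffices here: compound 4 at 2.1 nM and compound 2 at 3.3 nM lie within the scatter of each other. Nothing available on these compounds accounts for the lower number with the smaller group.

A single replacement cannot separate the contribution of fluoro itself from the loss of the sulfamoyl, so the reading of this carbon rests on one group. Plain hydrogen, chloro, methoxy, an amine or a carboxylic acid at the same place would show whether the low number is particular to fluoro or holds for other small groups, and whether a different group carrying hydrogen-bond donors can match it.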